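The source may report more compounds than this note shows. Statements on the series, on what has been measured and on what is new or still open speak of the compounds shown alone.

Measured compounds:
- compound 1 `COC(=O)c1cccc(C(=O)N2CCC(N(C3CC3)S(=O)(=O)c3cccc(C(F)(F)F)c3)CC2)c1`: "not determined" (no result reported)
- compound 2 `CS(=O)(=O)c1ccc(C(=O)N2CCC(N(C3CC3)S(=O)(=O)c3cccc(C(F)(F)F)c3)CC2)cc1`: "not determined" (no result reported)
- compound 3 `CS(=O)(=O)c1ccc(F)cc1C(=O)N1CCC(N(C2CC2)S(=O)(=O)c2cccc(C(F)(F)F)c2)CC1`: 34%

In an assay on cells for inhibition of Voltage-dependent L-type calcium channel subunit alpha-1C (Homo sapiens), read by FLIPR and calcium flux, tested at 3 uM (a lower number here means a weaker effect, a higher number a stronger effect of the compound at the concentration tested), compound 1 has no reported number, and compound 2 likewise gives no result; only compound 3 carries a value, 34%, a moderate read-out at the single concentration tested. Compound 1 therefore stands without a numerical anchor in this assay, and nothing in the series shows a step between two measured compounds.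

Compound 4 `CN(C)c1cccc(C(=O)N2CCC(N(C3CC3)S(=O)(=O)c3cccc(C(F)(F)F)c3)CC2)c1` differs from compound 1 by dimethylamino in place of methoxycarbonyl on an aromatic carbon. Among the measured compounds shown here, with no value for compound 1 and no measured step anywhere, the size and direction of this change in this assay cannot be read from the data; any effect beyond the scatter is unproven. For the measured compounds named here, compound 4 is expected to give 30%, with a range of 5% to 60%, close to the only measured value, that of compound 3.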

Compound 4, a percentage reported as inhibition, at one concentration (the size of the read-out at that concentration, not a potency): 63%
Compound 4: the middle estimate sits 33 percentage points below what was measured, outside the stated range (above it).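

In this assay, the series now has its first readable step, a number 29 percentage points higher from compound 3 to compound 4 (beyond the scatter), with 3-(dimethylamino)phenyl in place of 5-fluoro-2-(methylsulfonyl)phenyl on the carbonyl carbon. This step replaces the whole aryl group, and the steps involving compound 1 and compound 2 cannot be read, so the change from methoxycarbonyl to dimethylamino remains unsized. No supporting data bear on the origin of the step. Open, going by these compounds, is how a primary amine, a carboxylic acid or a diethylamino group at the same place would read out in this assay.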